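Working notes: compound 2 to compound 4, growth inhibition

The compounds below may be only part of what the source reports. "The series", "measured", "known", "first", "only" and "open" are said of these compounds alone.

Measured in a functional assay on KM12 cells (Homo sapiens) for inhibition, read by sulforhodamine B assay, with a stated time of 48 h; a higher number here means a weaker inhibitor of growth, a lower number a stronger inhibitor of growth:
compound 1 `Nc1cc(N)c2nc(-c3ccccc3)c(NCc3ccc(Cl)c(Cl)c3)nc2c1` gives 21400 nM
compound 2 `Nc1cc(N)c2nc(-c3ccccc3)c(Sc3ccc(F)cc3)nc2c1` gives 49000 nM
compound 3 `CCOC(=O)[C@H](CCC(=O)O)NC(=O)c1ccc(CNc2nc3cc(N)cc(N)c3nc2-c2ccccc2)cc1` gives only a limit, < 100000 nM

Compound 2 stands at the higher of the two numbers in this assay; the gap to compound 1 lies beyond the scatter. Compound 3 sits at the limit of < 100000 nM in this assay, at which 1 of the 3 values shown sits, which is a limit and not a number.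

Compound 4 `COc1ccc(Sc2nc3cc(N)cc(N)c3nc2-c2ccccc2)cc1` differs from compound 2 by methoxy in place of fluoro on an aromatic carbon, on an aromatic carbon of a six-membered aromatic ring of carbon only, para to a large group. For the measured compounds named here, no measured pair shows this change, so no size of step can be read from the series. The step from compound 2 to compound 4 is expected to be a 1.2-fold lower number from compound 2 to compound 4 (0.07 log units; within the scatter), none beyond the scatter. Compound 4 is estimated at 42000 nM, with a range from 15000 nM to 120000 nM.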

Compound 4, concentration for total growth inhibition: < 100000 nM
Compound 4 ended at the assay's limit; the forecaster's own chance of this, stated with the estimate: 20%; the middle value does not contradict the limit.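

For the compounds shown here, compound 4 gives < 100000 nM, a limit and not a number; no step from compound 2 to compound 4 can be read. From the compounds shown here alone, whether methoxy in place of fluoro changes growth inhibition at all stays open.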